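A few compounds are considered here, and "the series" means these few. Any claim that something is new, unique, unknown or untested is made for them only; others in the source may bear on it.

Working notes on the series. In a functional assay on MCF7 cells (Homo sapiens) for antiproliferative activity, read by MTT assay, with a stated time of 48 h (a higher number here means a weaker inhibitor, a lower number a stronger inhibitor), compound 1 `CCn1c(C(=O)NCCN)ccc1C(CC)(CC)c1ccc(OCCC(O)(CC)CC)c(C)c1`, which carries the 2-aminoethyl group, gives 670 nM. Compound 2 `CCn1c(C(=O)N(CCC#N)CCC#N)ccc1C(CC)(CC)c1ccc(OCCC(O)(CC)CC)c(C)c1` gives > 50000 nM, which is a limit of the assay. Compound 3 `CCn1c(C(=O)Nc2cccc(C(F)(F)F)c2)ccc1C(CC)(CC)c1ccc(OCCC(O)(CC)CC)c(C)c1` gives > 50000 nM, also a limit and not a number. Compound 3 therefore stands at the limit of > 50000 nM in this assay, at which 2 of the 3 values shown sit, and only compound 1 has a readable value.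

The next change leads to compound 4 `CCC(C)C(NC(=O)c1ccc(C(CC)(CC)c2ccc(OCCC(O)(CC)CC)c(C)c2)n1CC)C(=O)O`: 1-carboxy-2-methylbutyl in place of 3-(trifluoromethyl)phenyl on an amide-type nitrogen. In words, this is 1-carboxy-2-methylbutyl in place of 3-(trifluoromethyl)phenyl on an amide-type nitrogen. Going by the values given here, two measured steps bear on it, both large and both toward a higher number: an at least 74-fold higher number from compound 1 to compound 3 (1.87 log units; beyond the scatter), and an at least 74-fold higher number from compound 1 to compound 2 (1.87 log units; beyond the scatter). The remaining step, a step that the two limits leave unreadable from compound 2 to compound 3, gives no size to work with.

Compound 4 lacks the 2-aminoethyl group, so it is expected to lie nearer compound 3 than compound 1, going by an at least 74-fold higher number from compound 1 to compound 3 (1.87 log units; beyond the scatter). A reading that again returns only a limit is about as likely as a number. The expected step is an at least 2.0-fold lower number from compound 3 to compound 4 (0.30 log units; that floor lies within the scatter), a modest estimated move toward a lower number, left loose by the limit on its starting point. For compound 4 the estimated value is 25000 nM, with an expected range of 3000 nM to 50000 nM.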

Compound 4, half-maximal inhibitory concentration: 11300 nM
Beside the measured number, compound 4's estimate is 2.2-fold (0.34 log units) above it, within the range that was stated.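

With the 1-carboxy-2-methylbutyl group on the amide-type nitrogen, compound 4 gives a readable number in this assay, so a readable value at this position is not confined to the 2-aminoethyl group of compound 1, although the step is large, a 17-fold higher number from compound 1 to compound 4 (1.23 log units; beyond the scatter). Measured against the two compounds without a readable value, the change runs toward a lower number, with an at least 4.4-fold lower number from compound 3 to compound 4 (0.64 log units; beyond the scatter) and an at least 4.4-fold lower number from compound 2 to compound 4 (0.64 log units; beyond the scatter), and each of these sizes is only a floor set by a limit. Compound 2 and compound 3 remain limits of the assay and not numbers: the limit of > 50000 nM in this assay, at which 2 of the 4 values shown sit.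

On these data alone, it remains open whether the carboxylic acid or the branched carbon chain of compound 4 accounts for its step, and a methyl ester or a plain alkyl amide at the same nitrogen would separate the two. Also open, as far as these compounds go, is how a longer amine chain such as 3-aminopropyl, or a dimethylamino group at the end of the ethyl chain, would compare with the 2-aminoethyl group of compound 1.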